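The source may report more compounds than this note shows. Statements on the series, on what has been measured and on what is new or still open speak of the compounds shown alone.

Of the compounds shown here, two from this series have a number so far. Within the data shown here, compound 2 `COc1ccc2nc(NC(=O)c3cn(-c4ccccc4)nc3-c3ccc(Cl)cc3)sc2c1` gives 29600 nM in an ADME assay on HEK-293T cells (Homo sapiens) for cytotoxicity, read by MTT assay, with a stated time of 72 h; a lower number here means a stronger inhibitor, a higher number a weaker inhibitor; the only other number on hand, from compound 1 `O=C(Nc1nc2ccc(Cl)cc2s1)c1cn(-c2ccccc2)nc1-c1ccc(Cl)cc1`, is 15700 nM, and the two lie within the scatter of each other. Among the measured compounds shown here, the one step between them, a 1.9-fold higher number from compound 1 to compound 2 (0.28 log units; within the scatter), came from a methoxy replacing a chloro on an aromatic carbon and did not exceed the scatter. Compound 3 `Cc1ccc2nc(NC(=O)c3cn(-c4ccccc4)nc3-c3ccc(Cl)cc3)sc2c1` differs from compound 2 in one place: methyl in place of methoxy on an aromatic carbon. For the measured compounds named here, only the step from compound 1 to compound 2 bears on this change, and since it stayed within the scatter, no step beyond the scatter is expected in this assay, in either direction. Compound 3 is therefore estimated at 25000 nM, with a range from 10000 nM to 60000 nM, which amounts to an expected step of a 1.2-fold lower number from compound 2 to compound 3 (0.07 log units; within the scatter).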

Compound 3, half-maximal inhibitory concentration: 35600 nM
Compound 3: the middle estimate sits 1.4-fold (0.15 log units) below what was measured, and the stated range covers the measured number.
By their numbers in this assay, from the lowest: compounds 1, 2 and 3 (each within the scatter of the next, the first and the last beyond it).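

In this assay, methyl in place of methoxy on this aromatic carbon gives a 1.2-fold higher number from compound 2 to compound 3 (0.08 log units; within the scatter), so removing the methoxy oxygen, and with it the hydrogen-bond acceptor, does not move the number beyond the scatter in this pair. Methyl in place of chloro gives a 2.3-fold higher number from compound 1 to compound 3 (0.36 log units; beyond the scatter), a modest step and the first at this position to pass the scatter, which shows that the choice of group here can separate two compounds, if only slightly. Nothing on hand accounts for either step.

The compounds shown carry only chloro, methoxy and methyl at this position, so it remains open whether an amine, a carboxylic acid or a longer chain such as butoxy would shift the number further. On these data alone, whether the steps seen here would hold with the other parts of the shared core changed also remains open.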